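Working notes: the step from compound 3 to compound 4

A few compounds are considered here, and "the series" means these few. Any claim that something is new, unique, unknown or untested is made for them only; others in the source may bear on it.

- compound 1 `COc1cc(OCc2ccnc(N)n2)cc2sc(N[C@H]3CCCC[C@@H]3O)nc12`: 9.5 mL/min/kg
- compound 2 `CNC(=O)Nc1nccc(COc2cc(OC)c3nc(N[C@H]4CCCC[C@@H]4O)sc3c2)n1`: 23 mL/min/kg
- compound 3 `COc1cc(OCc2ccnc(Nc3cnoc3)n2)cc2sc(N[C@H]3CCCC[C@@H]3O)nc12`: 61 mL/min/kg

All three numbers come from an ADME assay on microsomes from liver (Homo sapiens) for pharmacokinetics, read by LC-MS, using NADPH, with a stated time of 45 min, tested at 1 uM; on this read-out higher numbers stand for fast clearance and lower numbers for slow clearance. There, compound 3 stands highest of the three at 61 mL/min/kg.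

Compound 4 `COc1cc(OCc2ccnc(Nc3cn(C)nn3)n2)cc2sc(N[C@H]3CCCC[C@@H]3O)nc12` carries 1-methyl-1H-1,2,3-triazol-4-yl in place of 1,2-oxazol-4-yl on a nitrogen on an aromatic ring.

Among the measured compounds shown here, three measured steps bear on this change. Methylcarbamoyl gave a 2.4-fold higher number from compound 1 to compound 2 (0.38 log units; beyond the scatter), and 1,2-oxazol-4-yl gave a 6.4-fold higher number from compound 1 to compound 3 (0.81 log units; beyond the scatter). The exchange of those two groups gave a 2.7-fold higher number from compound 2 to compound 3 (0.42 log units; beyond the scatter). All three are modest but beyond the scatter, and both groups raise the number over the unsubstituted compound 1. For the measured compounds named here, no compound goes against this, though only two substitutions have been measured. Going by the values given here, no measured compound carries the triazole, so its effect can only be inferred.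

Compound 4 keeps a substituent on that nitrogen, so a number above that of compound 1 is expected. Some fall from the top of the series is also expected, though the size is uncertain. In this assay, the estimated step is a 1.5-fold lower number from compound 3 to compound 4 (0.18 log units; within the scatter), a small drop that may not leave the scatter.

For compound 4 the expected value is 40 mL/min/kg, with an estimated range from 18 mL/min/kg to 80 mL/min/kg.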

Compound 4, clearance: 43 mL/min/kg
Estimate against measurement, compound 4: 1.1-fold (0.03 log units) below; measured number inside the range.
By their numbers in this assay, from the lowest: compound 1; then compounds 2, 4 and 3 (each within the scatter of the next, the first and the last beyond it).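

In this assay, 1-methyl-1H-1,2,3-triazol-4-yl in place of 1,2-oxazol-4-yl on this nitrogen gives a 1.4-fold lower number from compound 3 to compound 4 (0.15 log units; within the scatter), so this exchange of one five-membered aromatic ring for another cannot be told apart from repeat scatter. The triazole also gives a 1.9-fold higher number from compound 2 to compound 4 (0.27 log units; within the scatter) and therefore cannot be separated from methylcarbamoyl, even though the step between compound 2 and compound 3 lies beyond the scatter, while against hydrogen it gives a 4.5-fold higher number from compound 1 to compound 4 (0.66 log units; beyond the scatter), so all three substituents shown on this nitrogen now stand above the unsubstituted compound 1, with no compound going against this. No measurement shown here accounts for any of these steps.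

Still open, on these data alone, is whether any group on this nitrogen can keep the number close to that of compound 1, for instance a small alkyl group such as methyl or a saturated ring such as oxetane. Also open, as far as these compounds go, is what the methyl on the triazole contributes, which the unmethylated 1H-1,2,3-triazol-4-yl group would show as a single change from compound 4.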